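Phenol in place of dichlorophenyl: expected growth inhibition

The source may report more compounds than this note shows. Statements on the series, on what has been measured and on what is new or still open speak of the compounds shown alone.

Values in a functional assay on DU-145 cells (Homo sapiens) for inhibition; a lower number here means a stronger inhibitor of growth, a higher number a weaker inhibitor of growth:
- Compound 1 `N#Cc1ccc(/C=C/S(=O)(=O)Cc2ccc(Nc3ncnc4ccccc34)cc2)cc1`: > 100000 nM (a limit of the assay, not a number)
- Compound 2 `CC(C)(C)c1cc(/C=C/S(=O)(=O)Cc2ccc(Nc3ncnc4ccccc34)cc2)cc(C(C)(C)C)c1O`: 1000 nM
- Compound 3 `O=S(=O)(/C=C/c1ccc(Cl)c(Cl)c1)Cc1ccc(Nc2ncnc3ccc(Br)cc23)cc1`: 17000 nM

Of the two actual numbers, the higher belongs to compound 3 at 17000 nM. Compound 2 lies lower at 1000 nM, a gap beyond the usual scatter.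

Compound 4 `O=S(=O)(/C=C/c1ccc(O)cc1)Cc1ccc(Nc2ncnc3ccc(Br)cc23)cc1` has 4-hydroxyphenyl in place of the 3,4-dichlorophenyl of compound 3, on a double-bonded chain carbon bound to a double-bonded chain carbon (4-hydroxyphenyl in place of 3,4-dichlorophenyl on a double-bonded chain carbon bound to a double-bonded chain carbon). Going by the values given here, no measured pair differs in one place only, so this change has no direct precedent. Among the compounds with values here, compound 2 is the only measured compound with a hydroxyl, and its value of 1000 nM gives weak support for a move towards a lower number, although it differs from compound 4 in other places too. A moderate gain, probably beyond the scatter, is expected in this assay, with an estimated 3.4-fold lower number from compound 3 to compound 4 (0.53 log units; beyond the scatter). The estimate for compound 4 is 5000 nM, with an expected range of 700 nM to 30000 nM.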

Compound 4, concentration for 50% growth inhibition: 3000 nM
Compound 4: middle estimate off by 1.7-fold (0.22 log units), on the high side; the measured number falls inside the stated range.
By their numbers in this assay, from the lowest: compound 2; then compound 4; then compound 3. At a limit, above all of these: compound 1.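

On a double-bonded chain carbon bound to a double-bonded chain carbon, 4-hydroxyphenyl in place of 3,4-dichlorophenyl gives a 5.7-fold lower number from compound 3 to compound 4 (0.75 log units; beyond the scatter) in this assay with the rest of the structure unchanged. Going by these compounds alone, this is the only single-place comparison, and it shows that growth inhibition at this position depends on what the phenyl ring carries, by a margin beyond the scatter. The compounds shown offer no measurement that explains the step.

The step removes both chlorines and adds the hydroxyl at once, so the share of each change remains unresolved. A phenyl ring with a single chlorine, or with a methoxy group or an amine in place of the hydroxyl, would help separate these contributions on the same core.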